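Aryl swap on the ring nitrogen: expectation for compound 3

The source may report more compounds than this note shows. Statements on the series, on what has been measured and on what is new or still open speak of the compounds shown alone.

Compound 1 `O=C(/C=C/c1ccccc1)c1ccc(N2CCN(c3ccc([N+](=O)[O-])cc3)CC2)cc1`: 55.4%
Compound 2 `O=C(/C=C/c1ccccc1)c1ccc(N2CCN(c3ccccc3F)CC2)cc1`: 0.57%

Within the data shown here, in a functional assay on the whole organism (strain Kunming) for inhibition, with Mus musculus as the target, with a stated time of 1 h, at a dose of 40 mg/kg by the oral route (on this read-out lower numbers stand for less inhibition and higher numbers for more inhibition at the one dose given (going by the name of the read-out)), compound 2 stands lowest of the two numbers, and its only neighbour is compound 1, far higher. Among the measured compounds shown here, the one step measured so far, a number 54.8 percentage points lower from compound 1 to compound 2 (beyond the scatter), shows that the group on the ring nitrogen alone moves the read-out greatly. Compound 3 `O=C(/C=C/c1ccccc1)c1ccc(N2CCN(c3cccc(Cl)c3)CC2)cc1` is not yet measured; it differs from compound 2 by 3-chlorophenyl in place of 2-fluorophenyl on an amine nitrogen in a ring. That same position is altered, so a step beyond the scatter is possible in either direction, with nothing to fix its sign. Compound 3 is therefore expected at 20%, within 0% to 55%, an expected step of a number 19.4 percentage points higher from compound 2 to compound 3 (beyond the scatter).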

Compound 3, a percentage reported as inhibition, in the whole organism at one dose (the size of the read-out at that dose, not a potency): 14.1%
For compound 3 the middle estimate is 5.9 percentage points above the measured one, within the range that was stated.
By their numbers in this assay, from the lowest: compound 2; then compound 3; then compound 1.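

In this assay, the group on the amine nitrogen in a ring now gives three separate levels: 3-chlorophenyl in place of 2-fluorophenyl gives a number 13.5 percentage points higher from compound 2 to compound 3 (beyond the scatter), while in place of 4-nitrophenyl it gives a number 41.3 percentage points lower from compound 1 to compound 3 (beyond the scatter). The two halogen-bearing phenyl groups thus differ from each other, yet the gap from either to the 4-nitrophenyl of compound 1 remains much larger.

Still open, going by these compounds, are the separate contributions of the halogen and its ring location, which change together here, and the reading with an amine or a carboxylic acid on this phenyl ring. No data given here bear on the cause of these differences.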